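Aryl urea variation on the shared core

A few compounds are considered here, and "the series" means these few. Any claim that something is new, unique, unknown or untested is made for them only; others in the source may bear on it.

Three measured compounds share one core and differ only in the aryl group on the urea nitrogen. In a functional assay on HepG2 cells (Homo sapiens) for antiproliferative activity, read by MTT assay, with a stated time of 48 h (on this read-out lower numbers stand for stronger inhibition and higher numbers for weaker inhibition), compound 1 `O=C(Nc1cccc(CNc2nccnc2Cl)c1)Nc1ccccc1Cl` gives 8560 nM; compound 2 `O=C(Nc1cccc(CNc2nccnc2Cl)c1)Nc1ccccc1F` gives 10500 nM and compound 3 `O=C(Nc1cccc(CNc2nccnc2Cl)c1)Nc1ccc(Cl)cc1Br` gives 6720 nM. Compound 1 stands second highest of the three, with a 1.2-fold higher number from compound 1 to compound 2 (0.09 log units; within the scatter) and a 1.3-fold lower number from compound 1 to compound 3 (0.11 log units; within the scatter); a 1.6-fold lower number from compound 2 to compound 3 (0.19 log units; within the scatter) also stays within the scatter. Compound 4 `O=C(Nc1cccc(CNc2nccnc2Cl)c1)Nc1ccc(Cl)c(Cl)c1` is not yet measured. Its change from compound 1 is 3,4-dichlorophenyl in place of 2-chlorophenyl on an amide-type nitrogen. Going by the values given here, the steps that bear on it, from compound 1 to compound 3 and from compound 2 to compound 3, both alter the halogen pattern of the phenyl ring and remain within the scatter, so the expected step is a 1.1-fold lower number from compound 1 to compound 4 (0.06 log units; within the scatter), nothing beyond the scatter. The value expected for compound 4 is 7500 nM, with a range of 3500 nM to 16000 nM.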

Compound 4, half-maximal inhibitory concentration: 6170 nM
Compound 4: middle estimate off by 1.2-fold (0.08 log units), on the high side, and the stated range covers the measured number.
By their numbers in this assay, from the lowest: compounds 4, 3, 1 and 2 (each within the scatter of the next).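

Replacing 2-chlorophenyl with 3,4-dichlorophenyl on the amide-type nitrogen adds a second chlorine, and in this assay every new step stays within the scatter (a 1.4-fold lower number from compound 1 to compound 4 (0.14 log units; within the scatter); a 1.1-fold lower number from compound 3 to compound 4 (0.04 log units; within the scatter); a 1.7-fold lower number from compound 2 to compound 4 (0.23 log units; within the scatter)). The four halogen patterns at this position therefore cannot be separated on this read-out, even with the chlorine arrangement changed. No supporting measurement bears on this result. Open, going by these compounds, is whether a phenyl ring carrying methoxy, trifluoromethyl or a carboxylic acid, or a saturated cyclohexyl group in its place, would give a step beyond the scatter.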